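Swapping a Carboxyindole for a Benzothiophene

This account rests on a few compounds, and the source may have more. Where it says the series, first, only, none or still open, it means among the compounds named here.

Compound 1 `Cn1c(=O)c(S(=O)(=O)c2ccc(F)cc2F)cc2cnc(Nc3ccc4[nH]c(C(=O)O)cc4c3)nc21` was tested in a functional assay on DU-145 cells (Homo sapiens) for inhibition, read by trypan blue exclusion, with a stated time of 72 h (a higher number here means a weaker inhibitor, a lower number a stronger inhibitor), where compound 1 gives 10000 nM, the highest number of the two measured here. Compound 2 `CCCn1c(=O)c(S(=O)(=O)c2ccc(F)cc2F)cc2cnc(Nc3ccc4[nH]ccc4c3)nc21` gives 1000 nM in this assay, a lower number beyond the scatter. Compound 3 `Cn1c(=O)c(S(=O)(=O)c2ccc(F)cc2F)cc2cnc(Nc3ccc4sccc4c3)nc21` has not yet been measured; it differs from compound 1 by 1-benzothiophen-5-yl in place of 2-carboxy-1H-indol-5-yl on a nitrogen on an aromatic ring. With the group that leaves carrying two hydrogen-bond donors and the group that enters none, a step toward a lower number is expected for compound 3, estimated as a 5.0-fold lower number from compound 1 to compound 3 (0.70 log units; beyond the scatter), giving an expected value of 2000 nM, ranging from 500 nM to 10000 nM.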

Compound 3, half-maximal inhibitory concentration: 500 nM
Beside the measured number, compound 3's estimate is 4.0-fold (0.60 log units) above it; low and high end bracket the measured number.
By their numbers in this assay, from the lowest: compounds 3 and 2 (each within the scatter of the next); then compound 1.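

With 1-benzothiophen-5-yl in place of 2-carboxy-1H-indol-5-yl on the nitrogen, the change gives a 20-fold lower number from compound 1 to compound 3 (1.30 log units; beyond the scatter) in this assay. Compounds 1 and 2 differ in more than one place and could not isolate this position; here, only the group on that nitrogen changes, and the number moves well beyond the scatter. Nothing available explains this shift.

Going by these compounds, it remains open whether the step comes from losing the carboxylic acid or from the sulfur of the new ring. On these data alone, how an amide or an amine in place of that acid would read also remains open.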